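The source may report more compounds than this note shows. Statements on the series, on what has been measured and on what is new or still open speak of the compounds shown alone.

Working notes on the series in an ADME assay on BV-2 cells (Mus musculus) for cytotoxicity, with a stated time of 24 h, tested at 10 uM; a higher number here means a weaker effect of the compound at the concentration tested, a lower number a stronger effect. Compound 1 `COc1ccccc1S(=O)(=O)/C=C/c1ccccn1` gives 100%. Compound 2 `COc1ccccc1S(=O)(=O)/C=C/c1ncccc1F` differs from compound 1 by fluoro in place of hydrogen on an aromatic carbon; in this assay compound 2 gives 100%, and the step is no change at the digits printed from compound 1 to compound 2 (within the scatter). Compound 3 `COc1ccc(S(=O)(=O)/C=C/c2ccccn2)cc1` has a different core; how the core of compound 3 differs from that of compound 1 is not broken down here. In this assay compound 3 gives 100%, level with compounds 1 and 2 within the scatter. Compound 4 `COc1ccc(S(=O)(=O)/C=C/c2ncccc2F)cc1` is not yet measured; it differs from compound 3 by fluoro in place of hydrogen on an aromatic carbon, the same change as from compound 1 to compound 2. The step from compound 3 to compound 4 is expected to be no change at the digits printed from compound 3 to compound 4 (within the scatter), because the same change gave no change at the digits printed from compound 1 to compound 2 (within the scatter). Compound 4 is therefore estimated at 100%, with a range from 88% to 106%.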

Compound 4, a percentage reported as activity, at one concentration (the size of the read-out at that concentration, not a potency): 94.2%
Beside the measured number, compound 4's estimate is 5.8 percentage points above it, within the range that was stated.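

In this assay, fluoro in place of hydrogen on an aromatic carbon gives a number 5.8 percentage points lower from compound 3 to compound 4 (within the scatter). Set beside the earlier step, the result on the two cores does not differ: the same change on two cores in this assay, no change at the digits printed (within the scatter) from compound 1 to compound 2 and a number 5.8 percentage points lower (within the scatter) from compound 3 to compound 4, 5.8 percentage points apart, within the scatter of two such steps This shows that the change carries between these two cores without a step beyond the scatter, but it covers only two cores and one read-out at a single concentration, and it does not show that the same would hold on other cores or on a compound with a stronger effect.

Still open, on these data alone, is how a group other than fluoro at the same place, such as an amine, a carboxylic acid or a longer chain, would behave in this assay.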